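The Alkyne Chain Gives Way to a Thiophene

The source may report more compounds than this note shows. Statements on the series, on what has been measured and on what is new or still open speak of the compounds shown alone.

Compound 1 `CCCC#Cc1cc([C@@H]2O[C@H](CO)[C@@H](O)[C@H]2O)n2ncnc(N)c12` carries a pent-1-yn-1-yl chain on its core. Within the data shown here, in a functional assay on NCI-H460 cells (Homo sapiens) for antiproliferative activity, with a stated time of 72 h (on this read-out lower numbers stand for stronger inhibition and higher numbers for weaker inhibition), compound 1 gives 400 nM, the only numeric value among the three compounds measured so far. Compound 2 `Nc1ncnn2c([C@@H]3O[C@H](CO)[C@@H](O)[C@H]3O)cc(-c3ccccc3)c12` bears phenyl in the same place, and in this assay compound 2 reaches a limit of > 100000 nM. Compound 3 `Cc1ccccc1-c1cc([C@@H]2O[C@H](CO)[C@@H](O)[C@H]2O)n2ncnc(N)c12` bears 2-methylphenyl, and in this assay compound 3 likewise gives a limit of > 100000 nM. Thus an at least 250-fold higher number from compound 1 to compound 2 (2.39 log units; beyond the scatter) and an at least 250-fold higher number from compound 1 to compound 3 (2.39 log units; beyond the scatter); a step that the two limits leave unreadable from compound 2 to compound 3. Compound 4 `Nc1ncnn2c([C@@H]3O[C@H](CO)[C@@H](O)[C@H]3O)cc(-c3ccsc3)c12` is not yet measured; it differs from compound 1 by thiophen-3-yl in place of pent-1-yn-1-yl on an aromatic carbon. Because both aromatic replacements gave (the limit of > 100000 nM in this assay, at which 2 of the 3 values shown sit), a large loss is expected in this assay. Compound 4 is therefore estimated at 50000 nM, within 5000 nM to 200000 nM, which means an expected 130-fold higher number from compound 1 to compound 4 (2.10 log units; beyond the scatter).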

Compound 4, half-maximal inhibitory concentration: 35600 nM
For compound 4 the middle estimate is 1.4-fold (0.15 log units) above the measured one; low and high end bracket the measured number.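

Thiophen-3-yl gives the first measured number for an aromatic ring at this position, so the loss from leaving the chain can now be sized, with an 89-fold higher number from compound 1 to compound 4 (1.95 log units; beyond the scatter). Aromatic rings here also differ among themselves, with an at least 2.8-fold lower number from compound 2 to compound 4 (0.44 log units; beyond the scatter) and an at least 2.8-fold lower number from compound 3 to compound 4 (0.44 log units; beyond the scatter). Even so, of the four compounds only the pent-1-yn-1-yl chain gives strong inhibition in this assay.

Still open, on these data alone, is whether the triple bond matters or the chain alone, which a saturated pentyl chain would test. A shorter alkyne, or an amine at this position, also remains untested in what is shown here.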